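Hydroxy to methoxy: the step from compound 2 to compound 3

The source may report more compounds than this note shows. Statements on the series, on what has been measured and on what is new or still open speak of the compounds shown alone.

Among the measured compounds shown here, in a functional assay on SNB-19 cells (Homo sapiens) for inhibition, read by sulforhodamine B assay, with a stated time of 48 h, tested at 10 uM (on this read-out higher numbers stand for a weaker effect at the one concentration tested and lower numbers for a stronger effect), compound 1 `O=C(Nc1cccc(-n2cc(-c3ccncc3)c(-c3cc(O)cc(Cl)c3)n2)c1)Nc1ccc(Cl)c(C(F)(F)F)c1` gives 44.5% and compound 2 `O=C(Nc1cccc(-n2cc(-c3ccncc3)c(-c3cc(O)cc(Cl)c3)n2)c1)Nc1ccc(Cl)c(Cl)c1` gives 30.8%, the lower of the two numbers; the only measured step, a number 13.7 percentage points lower from compound 1 to compound 2 (beyond the scatter), concerns a different position. Compound 3 `COc1cc(Cl)cc(-c2nn(-c3cccc(NC(=O)Nc4ccc(Cl)c(Cl)c4)c3)cc2-c2ccncc2)c1` differs from compound 2 by methyl in place of hydrogen on an oxygen on an aromatic ring. For the measured compounds named here, no measured step bears on this change, so the expectation rests on compound 2 alone: a step of a number 7.2 percentage points higher from compound 2 to compound 3 (within the scatter) is estimated, within the scatter. Compound 3 is therefore expected to give about 38%, in a range of 18% to 60%.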

Compound 3, a percentage reported as activity, at one concentration (the size of the read-out at that concentration, not a potency): 17.8%
Compound 3: middle estimate off by 20.2 percentage points, on the high side; the measured number lies below the stated range.
By their numbers in this assay, from the lowest: compound 3; then compound 2; then compound 1.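

In this assay, methyl in place of hydrogen on the oxygen gives a number 13 percentage points lower from compound 2 to compound 3 (beyond the scatter), a stronger effect at the one concentration tested. Among the compounds shown here, this is the only measured change at this position, and in this pair the hydrogen on that oxygen is not needed for the effect. No measured evidence on hand accounts for this step.

Still open, from the compounds shown here alone, is whether a longer chain on this oxygen, such as ethoxy, or an amine in place of the hydroxy would strengthen or weaken the effect. Also open, going by these compounds, is whether methoxy gives a similar step alongside the trifluoromethyl of compound 1.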